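The source may report more compounds than this note shows. Statements on the series, on what has been measured and on what is new or still open speak of the compounds shown alone.

- Compound 1 `NC(=O)[C@@H]1[C@H](Nc2nc(Nc3cccc(C(=O)N4CCCC4)c3)ncc2-c2ccccc2)[C@H]2C=C[C@@H]1C2`: 220 nM
- Compound 2 `NC(=O)[C@@H]1[C@H](Nc2nc(Nc3cccc(C(=O)N4CCCC4)c3)ncc2-c2cccc(F)c2)[C@H]2C=C[C@@H]1C2`: 870 nM

In a functional assay on THP-1 cells (Homo sapiens) for inhibition, read by ELISA, with stated times of 1 h and 18 h (on this read-out higher numbers stand for weaker inhibition and lower numbers for stronger inhibition), compound 2 has the higher of the two numbers, 870 nM. Compound 3 `NC(=O)[C@@H]1[C@H](Nc2nc(Nc3cccc(-c4cnco4)c3)ncc2-c2cccc(F)c2)[C@H]2C=C[C@@H]1C2` differs from it in one group: 1,3-oxazol-5-yl in place of (pyrrolidin-1-yl)carbonyl on an aromatic carbon. In words, this is 1,3-oxazol-5-yl in place of (pyrrolidin-1-yl)carbonyl on an aromatic carbon. Within the data shown here, the only measured step, a 4.0-fold higher number from compound 1 to compound 2 (0.60 log units; beyond the scatter), is a different change, fluoro in place of hydrogen, so it bears only indirectly by showing how far one edit can move the number. No firm direction can be expected, and a step no larger than that one seems likely. The expected change is a 1.7-fold lower number from compound 2 to compound 3 (0.24 log units; within the scatter). The estimated value for compound 3 is 500 nM, with an expected range of 100 nM to 2500 nM.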

Compound 3, half-maximal inhibitory concentration: 390 nM
For compound 3 the middle estimate is 1.3-fold (0.11 log units) above the measured one; low and high end bracket the measured number.
By their numbers in this assay, from the lowest: compounds 1 and 3 (each within the scatter of the next); then compound 2.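

Replacing (pyrrolidin-1-yl)carbonyl with 1,3-oxazol-5-yl gives a 2.2-fold lower number from compound 2 to compound 3 (0.35 log units; beyond the scatter) in this assay. This position on the aromatic ring therefore does not depend on the carbonyl-linked non-aromatic ring, as a five-membered aromatic ring is accepted there with modestly stronger inhibition. No evidence is at hand to explain this shift.

From the compounds shown here alone, it remains open whether the same swap would have a similar effect with the unsubstituted phenyl of compound 1. Going by these compounds, it is also open how an amine or a carboxylic acid would fare at this position.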